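A few compounds are considered here, and "the series" means these few. Any claim that something is new, unique, unknown or untested is made for them only; others in the source may bear on it.

Of the compounds shown here, three sharing one core have been tested in an assay on isolated protein for inhibition of matrix metalloproteinase-9 (Homo sapiens); on this read-out lower numbers stand for stronger inhibition and higher numbers for weaker inhibition. Compound 1 `Cc1ccc(Sc2ccc(N(C[C@H](O)C(=O)NO)S(C)(=O)=O)cc2)cc1` gives 54 nM, compound 2 `CS(=O)(=O)N(C[C@H](O)C(=O)NO)c1ccc(Sc2ccc(F)cc2)cc1` gives 104 nM, and compound 3 `Cc1ccc(C#Cc2ccc(N(C[C@H](O)C(=O)NO)S(C)(=O)=O)cc2)cc1` gives 44 nM, the lowest number of the three; compound 1 sits nearest, within the scatter, while compound 2 lies furthest, with a 2.4-fold lower number from compound 2 to compound 3 (0.37 log units; beyond the scatter). Compound 4 `CS(=O)(=O)N(C[C@H](O)C(=O)NO)c1ccc(C#Cc2ccc(Cl)cc2)cc1` differs from compound 3 by chloro in place of methyl on an aromatic carbon. Among the measured compounds shown here, the only comparable step, a 1.9-fold higher number from compound 1 to compound 2 (0.28 log units; within the scatter), likewise trades a methyl for a halogen and stayed within the scatter; no measured step makes the trade to chloro. A step of similar size is therefore expected in this assay, a 1.4-fold higher number from compound 3 to compound 4 (0.13 log units; within the scatter). Compound 4 is estimated at 60 nM, with a likely range from 25 nM to 140 nM.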

Compound 4, half-maximal inhibitory concentration: 47 nM
For compound 4 the middle estimate is 1.3-fold (0.11 log units) above the measured one; the range from low to high includes it.
By their numbers in this assay, from the lowest: compounds 3, 4, 1 and 2 (each within the scatter of the next, the first and the last beyond it).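

Among the compounds shown here, the chloro and methyl versions of the ethynyl compound cannot be told apart in this assay (a 1.1-fold higher number from compound 3 to compound 4 (0.03 log units; within the scatter)), the first direct reading of chloro on this ring. Compound 4 also stays within the scatter of the methylphenyl sulfanyl compound (a 1.1-fold lower number from compound 1 to compound 4 (0.06 log units; within the scatter)), yet it stands clear of the fluorophenyl sulfanyl compound (a 2.2-fold lower number from compound 2 to compound 4 (0.34 log units; beyond the scatter)). Nothing available explains these results. Going by these compounds, whether a different group at this spot, such as an amine or a carboxylic acid, would keep the number in this range remains open.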